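Compound 3 to compound 4: allyl replaced by phenyl

This account rests on a few compounds, and the source may have more. Where it says the series, first, only, none or still open, it means among the compounds named here.

Measured so far in an ADME assay on cells (Erythrocyte, Homo sapiens), read by spectrophotometry and hemolysis, with a stated time of 24 h; a higher number here means a weaker inhibitor, a lower number a stronger inhibitor:
- compound 1 `CC1(C)[N+]([O-])=c2ccc(COc3ccccc3/C=N\NC(=N)N)cc2=[N+]1[O-]`: 114 uM
- compound 2 `CC1(C)[N+]([O-])=c2ccc(COc3ccccc3/C=N\NC(N)=S)cc2=[N+]1[O-]`: > 200 uM, a limit
- compound 3 `C=CCNC(=S)N/N=C\c1ccccc1OCc1ccc2c(c1)=[N+]([O-])C(C)(C)[N+]=2[O-]`: "nd(insoluble)" (no result reported)

Compound 3 stands without a number, so it gives no starting value for the next step. The nearest reference is the limit of > 200 uM in this assay, at which 1 of the 3 values shown sits. Compound 3 carries the thiocarbonyl group also found in compound 2. Compound 2 has an entry of > 200 uM, which is a limit.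

Compound 4 `CC1(C)[N+]([O-])=c2ccc(COc3ccccc3/C=N\NC(=S)Nc3ccccc3)cc2=[N+]1[O-]` is the next structure to be read. The change is phenyl in place of allyl on an amide-type nitrogen.

Among the compounds with values here, the only measured step is an at least 1.7-fold higher number from compound 1 to compound 2 (0.24 log units; that floor lies within the scatter). It concerns a different change on an amine nitrogen, and no measurement in the series covers an allyl or phenyl group at this place. No size or direction of step from compound 3 can therefore be stated in this assay. The expectation rests on compound 2 and its limit of > 200 uM, with a weak reading in this assay the likeliest outcome and a reported limit quite possible.

For compound 4 the expected value is 180 uM, with an estimated range of 80 uM to 400 uM.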

Compound 4, concentration for 50% inhibition: 66 uM
The estimate for compound 4 lay 2.7-fold (0.44 log units) above the measured number; measured number outside the range, below it.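

In this assay, within the data shown here, the thiourea-type side chain now has a measured number at this position: phenyl on the amide-type nitrogen, in place of hydrogen, gives an at least 3.0-fold lower number from compound 2 to compound 4 (0.48 log units; beyond the scatter), the first step beyond the scatter and the first showing that a substituent on this nitrogen registers in the hemolysis read-out. The hydrogen end of that step is not a number, and compound 2 holds it only as a limit: the limit of > 200 uM in this assay, at which 1 of the 4 values shown sits. Set against compound 1, which carries no thiocarbonyl group, the result is a 1.7-fold lower number from compound 1 to compound 4 (0.24 log units; within the scatter), so replacing the whole end group with this larger phenyl-bearing group leaves the reading within the scatter and gives no order between the two compounds.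

The step from compound 3 to compound 4 cannot be read, since compound 3 has no reported result, and allyl and phenyl therefore remain uncompared at this place. Going by these compounds, it also remains open whether a methyl, a benzyl or a phenyl carrying a carboxylic acid on this nitrogen would give a reading like that of compound 4.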